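This account rests on a few compounds, and the source may have more. Where it says the series, first, only, none or still open, it means among the compounds named here.

Compound 1 `COc1ccccc1Nc1cc(C)nc(SCc2nc3ccccc3[nH]2)n1`, compound 2 `Cc1cc(NCCO)nc(SCc2nc3ccccc3[nH]2)n1` and compound 3 `Cc1cc(N(C)Cc2ccccc2)nc(SCc2nc3ccccc3[nH]2)n1` share one core and differ only in the group on one aromatic carbon. In a functional assay on ECa-109 cells (Homo sapiens) for cytotoxicity, read by MTT assay, with a stated time of 72 h (on this read-out higher numbers stand for weaker inhibition and lower numbers for stronger inhibition), compound 1 gives 34400 nM. For compound 2 the result is a limit of the assay, > 100000 nM. For compound 3 the result is likewise a limit, > 100000 nM, so compound 3 stands at the weak end of what these numbers can show; two of the three values sit at that limit (the limit of > 100000 nM in this assay, at which 2 of the 3 values shown sit). Compound 4 `Cc1cc(Nc2ccc(Cl)cc2)nc(SCc2nc3ccccc3[nH]2)n1` has not yet been measured. It differs from compound 3 in one place: (4-chlorophenyl)amino in place of benzyl(methyl)amino on an aromatic carbon. Among the measured compounds shown here, the measured step that bears on this is the reverse of the one where the swap to benzyl(methyl)amino gave an at least 2.9-fold higher number from compound 1 to compound 3 (0.46 log units; beyond the scatter). The step that the two limits leave unreadable from compound 2 to compound 3 cannot be read. As compound 1, carrying an amino group with a hydrogen-bond donor, gives 34400 nM, compound 4 is expected to return a number of that kind, a drop of an at least 3.3-fold lower number from compound 3 to compound 4 (0.52 log units; beyond the scatter). Compound 4 is estimated at 30000 nM, between 8000 nM and 120000 nM.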

Compound 4, half-maximal inhibitory concentration: 20400 nM
For compound 4 the middle estimate is 1.5-fold (0.17 log units) above the measured one; measured number inside the range.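

In this assay, among the compounds shown here, the swap to (4-chlorophenyl)amino gives an at least 4.9-fold lower number from compound 3 to compound 4 (0.69 log units; beyond the scatter), and putting 4-chlorophenyl on the nitrogen in place of 2-hydroxyethyl gives an at least 4.9-fold lower number from compound 2 to compound 4 (0.69 log units; beyond the scatter), so compound 1 is no longer the only compound here with a number rather than a limit. Exchanging 2-methoxyphenyl for 4-chlorophenyl on that nitrogen gives a 1.7-fold lower number from compound 1 to compound 4 (0.23 log units; within the scatter), so these two substituted phenyl groups cannot be told apart in this assay. The first two steps give only minimum sizes because compound 2 and compound 3 sit at a limit: the limit of > 100000 nM in this assay, at which 2 of the 4 values shown sit.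

The compounds shown do not separate the effect of the hydrogen on the nitrogen from that of the ring sitting directly on it; plain benzylamino would fall between compound 3 and compound 4. Going by these compounds, how an unsubstituted phenyl or a 4-fluorophenyl group on that nitrogen would read also remains open.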